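From compound 3 to compound 4: chloro for oxan-4-yl

The source may hold more compounds than are shown below. What is called first, only, known or untested is meant among the compounds shown, and "the series" means these compounds.

compound 1 `Cc1cc2c(cn1)Oc1ccc(NC(=O)c3ccc(Cl)cn3)cc1[C@@]21COC(N)=N1`: 40 nm/s
compound 2 `NC1=N[C@@]2(CO1)c1cc(NC(=O)c3ccc(Cl)cn3)ccc1Oc1cnc(C3CC3)cc12`: 29 nm/s
compound 3 `NC1=N[C@@]2(CO1)c1cc(NC(=O)c3ccc(Cl)cn3)ccc1Oc1cnc(C3CCOCC3)cc12`: 27 nm/s

In an ADME assay on LLC-PK1 cells (Sus scrofa) for permeability, read by LC-MS, with a stated time of 2 h, tested at 5 uM (a lower number here means that the compound crosses the layer more slowly, a higher number that the compound crosses the layer faster), compound 3 gives 27 nm/s, which does not separate it from the other two compounds. The measured steps to it are a 1.1-fold lower number from compound 2 to compound 3 (0.03 log units; within the scatter) and a 1.5-fold lower number from compound 1 to compound 3 (0.17 log units; within the scatter).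

The next change leads to compound 4 `NC1=N[C@@]2(CO1)c1cc(NC(=O)c3ccc(Cl)cn3)ccc1Oc1cnc(Cl)cc12`, with chloro in place of oxan-4-yl on an aromatic carbon.

The three measured compounds differ only at this carbon, so all their steps bear on the change. Besides the two above, there is a 1.4-fold lower number from compound 1 to compound 2 (0.14 log units; within the scatter). None of these steps involves chloro, so the data offer only an indirect guide. With methyl, cyclopropyl and oxan-4-yl all staying within the scatter, no step beyond the scatter is expected in this assay, and no direction is expected with any confidence. The estimated step is a 1.2-fold higher number from compound 3 to compound 4 (0.07 log units; within the scatter). For compound 4 the expected value is 32 nm/s, with an estimated range of 18 nm/s to 55 nm/s.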

Compound 4, apparent permeability: 28 nm/s
Compound 4: the middle estimate sits 1.1-fold (0.06 log units) above what was measured, within the range that was stated.
By their numbers in this assay, from the lowest: compounds 3, 4, 2 and 1 (each within the scatter of the next).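

In this assay, replacing oxan-4-yl with chloro on this aromatic carbon takes away a six-membered non-aromatic ring and leaves a single chlorine, yet the result is a 1.0-fold higher number from compound 3 to compound 4 (0.02 log units; within the scatter). The comparisons with the two smaller carbon groups give a 1.0-fold lower number from compound 2 to compound 4 (0.02 log units; within the scatter) and a 1.4-fold lower number from compound 1 to compound 4 (0.15 log units; within the scatter), so chloro extends the set at this place beyond carbon-linked groups without any step leaving the scatter. No supporting measurement accounts for this flat picture.

On these data alone, whether an amine or a carboxylic acid at this carbon would give a step beyond the scatter remains open, as does the outcome for a longer chain such as n-butyl. The compounds shown also leave open whether this flat picture would hold with a different group in place of the chloro on the amide side of the shared core.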